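The source may hold more compounds than are shown below. What is called first, only, known or untested is meant among the compounds shown, and "the series" means these compounds.

Compound 3 `Nc1nccc(-c2ccc3nc(C4COc5ccccc5C4)oc3c2)n1` stands in an assay on cells for inhibition of Rho-associated protein kinase 2 (Homo sapiens) (a higher number here means a weaker inhibitor, a lower number a stronger inhibitor), with "not determined" (no result reported): no result was reported for it, and compound 2 `CC(C)Oc1ccc2c(c1)CC(c1nc3ccc(-c4ccnc(N)n4)cc3[nH]1)CO2` is a further entry in this assay with "not determined" (no result reported). Within the data shown here, the only value at hand comes from compound 1 `c1ccc2c(c1)CC(c1nc3ccc(-c4cn[nH]c4)cc3[nH]1)CO2`, which in this assay gives 86 nM. Compound 4 `Cc1[nH]ncc1-c1ccc2nc(C3COc4ccccc4C3)oc2c1` has not yet been measured in this assay. Set against compound 3 it differs in one place: 5-methyl-1H-pyrazol-4-yl in place of 2-aminopyrimidin-4-yl on an aromatic carbon. Among the measured compounds shown here, no step between two measured compounds has been recorded, so there is no measured anchor for the size or direction of this change, and with compound 3 itself lacking a number, the step from compound 3 to compound 4 cannot be sized against anything. He therefore expects no shift that could be called larger than the scatter in this assay, and no firm direction. Compound 4 is expected to give 150 nM in this assay, within a range from 40 nM to 600 nM, an estimate that rests on compound 1 with its 86 nM as the nearest reference.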

Compound 4, half-maximal inhibitory concentration: 533 nM
Beside the measured number, compound 4's estimate is 3.6-fold (0.55 log units) below it, and the stated range covers the measured number.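

Among these compounds, compound 3 carries no number in this assay, so no step to compound 4 can be read. The compounds shown leave open how 5-methyl-1H-pyrazol-4-yl compares with 2-aminopyrimidin-4-yl on this core. No evidence bears on the result.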